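A few compounds are considered here, and "the series" means these few. Any claim that something is new, unique, unknown or untested is made for them only; others in the source may bear on it.

Working notes on the shared core, read in a functional assay on HT-29 cells (Homo sapiens) for cytotoxicity, read by MTT assay; on this read-out higher numbers stand for weaker inhibition and lower numbers for stronger inhibition. Compound 1 (`C=C1C(=O)[C@]23C[C@@]1(Cl)CC[C@H]2[C@@]12C=CC(=O)[C@](C)(C(=O)O1)[C@H]2[C@@H]3C(=O)OCc1ccccc1`) gives 4500 nM, compound 2 (`C=C1C(=O)[C@]23C[C@@]1(O)CC[C@H]2[C@@]12C=CC(=O)[C@](C)(C(=O)O1)[C@H]2[C@@H]3C(=O)OCc1ccccc1`) gives 83300 nM and compound 3 (`C=C1C(=O)[C@]23C[C@@]1(I)CC[C@H]2[C@@]12C=CC(=O)[C@](C)(C(=O)O1)[C@H]2[C@@H]3C(=O)OC`) gives 51900 nM. Compound 3 therefore lies within the scatter of compound 2 and well beyond the scatter of compound 1, which holds the lowest number of the three.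

Compound 4 (`C=C1C(=O)[C@]23C[C@@]1(I)CC[C@H]2[C@@]12C=CC(=O)[C@](C)(C(=O)O1)[C@H]2[C@@H]3C(=O)OCc1ccccc1`) keeps the iodo group of compound 3 and changes the ester: phenyl in place of hydrogen on a saturated chain carbon bound to an oxygen next to a carbonyl group. This is phenyl in place of hydrogen on a saturated chain carbon bound to an oxygen next to a carbonyl group, or methoxycarbonyl to benzyloxycarbonyl.

Going by the values given here, no measured step covers this change directly. The only one, a 19-fold higher number from compound 1 to compound 2 (1.27 log units; beyond the scatter), is large, but it is hydroxy in place of chloro with benzyloxycarbonyl held constant, so it gives no size for the ester change. It does show that the number among benzyloxycarbonyl compounds moves with that other group. Compound 4 differs from compound 1 only in iodo for chloro, and compound 1 reads 4500 nM, although the gap between compound 3 and compound 1 mixes both changes.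

A move toward a lower number, beyond the scatter, is expected in this assay, with an estimated size of a 6.5-fold lower number from compound 3 to compound 4 (0.81 log units; beyond the scatter). The estimate for compound 4 is 8000 nM, with an expected range from 2500 nM to 25000 nM.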

Compound 4, half-maximal inhibitory concentration: 50200 nM
For compound 4 the middle estimate is 6.3-fold (0.80 log units) below the measured one; measured number outside the range, above it.
By their numbers in this assay, from the lowest: compound 1; then compounds 4, 3 and 2 (each within the scatter of the next).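

In this assay the ester change, read with iodo held constant, is a 1.0-fold lower number from compound 3 to compound 4 (0.01 log units; within the scatter) and so lies within the scatter: among the iodo compounds, phenyl in place of hydrogen on a saturated chain carbon bound to an oxygen next to a carbonyl group leaves the number unresolved from that of the methoxycarbonyl compound. With benzyloxycarbonyl held constant, the group on the saturated ring carbon does separate the compounds, since chloro to iodo gives an 11-fold higher number from compound 1 to compound 4 (1.05 log units; beyond the scatter) while hydroxy to iodo gives only a 1.7-fold lower number from compound 2 to compound 4 (0.22 log units; within the scatter) and stays within the scatter, so that chloro alone stands apart among these three groups at this place. Nothing available accounts for this separation of chloro from iodo and hydroxy.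

Whether the ester change is equally silent with chloro on the saturated ring carbon stays open, as the compounds shown pair methoxycarbonyl with iodo only. Also open, as far as these compounds go, is how bromo, fluoro or an amine on that ring carbon would read, and how a carboxylic acid or a longer chain would read in place of the benzyl ester.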